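Amide side chain change in the cytotoxicity series

The source may hold more compounds than are shown below. What is called first, only, known or untested is meant among the compounds shown, and "the series" means these compounds.

For the measured compounds named here, in a functional assay on CLL cells (Homo sapiens) for cytotoxicity, read by MTT assay, with a stated time of 48 h (a lower number here means that less compound is needed, a higher number that more compound is needed for the effect), compound 1 (`C=C(CC)C(=O)c1ccc(OCC(=O)NCCCN2CCCC2=O)c(Cl)c1Cl`) gives 13800 nM, the higher of the two numbers so far. Compound 2 (`C=C(CC)C(=O)c1ccc(OCC(=O)Nc2ccc3c(c2)C(=O)NC3=O)c(Cl)c1Cl`), with another amide substituent on the shared core, gives 2500 nM, a gap beyond the scatter. Compound 3 (`C=C(CC)C(=O)c1ccc(OCC(=O)NCO[N+](=O)[O-])c(Cl)c1Cl`) carries nitrooxy in place of 2-(2-oxopyrrolidin-1-yl)ethyl on a saturated chain carbon bound to an amide-type nitrogen. Going by the values given here, no measured step isolates this change, and the only guide is that the amide substituent differs between compound 1 and compound 2. A modest move toward a lower number is expected, with an estimated 2.3-fold lower number from compound 1 to compound 3 (0.36 log units; beyond the scatter). For compound 3 the expected value is 6000 nM, with an estimated range of 2000 nM to 18000 nM.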

Compound 3, half-maximal effective concentration: 4100 nM
Estimate against measurement, compound 3: 1.5-fold (0.17 log units) above; the measured number falls inside the stated range.
By their numbers in this assay, from the lowest: compounds 2 and 3 (each within the scatter of the next); then compound 1.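

For the compounds shown here, at this saturated chain carbon bound to an amide-type nitrogen, nitrooxy in place of 2-(2-oxopyrrolidin-1-yl)ethyl gives the first single-place step in this assay, a 3.4-fold lower number from compound 1 to compound 3 (0.53 log units; beyond the scatter). The five-membered non-aromatic ring of compound 1 is therefore not needed at this position for a lower number. No available data explain the step.

Open, as far as these compounds go, is whether the lower number follows the nitrooxy group or the change in the chain. A hydroxyl, an amine or a carboxylic acid at this carbon, or nitrooxy on a longer chain, would separate the two.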